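Oxygen-linked side chains on a bicyclic acid core

The source may hold more compounds than are shown below. What is called first, only, known or untested is meant among the compounds shown, and "the series" means these compounds.

Three compounds share the core of compound 1 `CCCCCCCCOCC1C2CCC(O2)C1C/C=C\CCCC(=O)O` and differ only in the group carried on the saturated chain carbon bound to an oxygen on a saturated carbon. In a functional assay (plasma) for inhibition, with Homo sapiens as the target (a higher number here means a weaker inhibitor, a lower number a stronger inhibitor), compound 1 gives 32000 nM, the second highest of the three numbers. Compound 2 `O=C(O)CCC/C=C\CC1C2CCC(O2)C1COCCCc1ccccc1` gives 26000 nM; the change a 1.2-fold lower number from compound 1 to compound 2 (0.09 log units; within the scatter) is within the scatter. Compound 3 `O=C(O)CCC/C=C\CC1C2CCC(O2)C1COCC1CCCCC1` gives 165000 nM; here a 5.2-fold higher number from compound 1 to compound 3 (0.71 log units; beyond the scatter) and a 6.3-fold higher number from compound 2 to compound 3 (0.80 log units; beyond the scatter) are both beyond the scatter.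

Compound 4 `CCC/C=C\COCC1C2CCC(O2)C1C/C=C\CCCC(=O)O` is not yet measured. It differs from compound 1 as follows: pent-1-en-1-yl in place of heptyl on a saturated chain carbon bound to an oxygen on a saturated carbon. The step that bears on it most is the replacement at the same place in compound 3, where a 5.2-fold higher number from compound 1 to compound 3 (0.71 log units; beyond the scatter) shows a modest weakening when heptyl is shortened and given a ring. Compound 4 also shortens the chain but keeps it open and adds a double bond, so the two changes do not match closely. The expectation for compound 4 is therefore a small rise in number, a 1.6-fold higher number from compound 1 to compound 4 (0.19 log units; within the scatter), with the range wide enough to include no change beyond the scatter. Compound 4 is expected to give about 50000 nM in this assay, between 15000 nM and 160000 nM.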

Compound 4, half-maximal inhibitory concentration: 3300 nM
Compound 4: middle estimate off by 15-fold (1.18 log units), on the high side, outside the stated range (below it).
By their numbers in this assay, from the lowest: compound 4; then compounds 2 and 1 (each within the scatter of the next); then compound 3.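

In this assay, this position can also lower the number substantially (a 9.7-fold lower number from compound 1 to compound 4 (0.99 log units; beyond the scatter)), whereas the earlier replacements of heptyl either stayed within the scatter, as with compound 2, or raised the number, as with compound 3. The pent-1-en-1-yl group also separates clearly from phenethyl (a 7.9-fold lower number from compound 2 to compound 4 (0.90 log units; beyond the scatter)) and from cyclohexyl (a 50-fold lower number from compound 3 to compound 4 (1.70 log units; beyond the scatter)), the latter being the largest step in the set, and compound 4 is the strongest inhibitor of the four, with its steps to all three others beyond the scatter. No supporting evidence is available to explain this result.

The step from compound 1 to compound 4 both shortens the chain and adds a double bond, so the compounds shown do not say which of these changes goes with the lower number. A pentyl group on the same saturated chain carbon, which keeps the shorter length without the double bond, and a hept-1-en-1-yl group, which keeps the double bond on a longer chain, would separate the two.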